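This account rests on a few compounds, and the source may have more. Where it says the series, first, only, none or still open, it means among the compounds named here.

Measured so far:
- compound 1, `COc1ccc(C2=NN(C3=NC(=O)/C(=C4\C(=O)Nc5ccccc54)S3)C(c3ccc(OC)cc3)C2)cc1`: in a functional assay on cells (Cancer cell lines, Homo sapiens) for cytotoxicity, read by sulforhodamine B assay, with a stated time of 48 h (a higher number here means a weaker inhibitor of growth, a lower number a stronger inhibitor of growth), compound 1 gives 100000 nM
- compound 2, `O=C1N=C(N2N=C(c3ccccc3)CC2c2ccc(Cl)cc2)S/C1=C1/C(=O)Nc2ccccc21`: in this assay compound 2 gives 190 nM

Compound 2 holds the lowest of the two numbers. Its nearest neighbour in this assay is compound 1, whose number is higher by a margin that lies well beyond the scatter of repeated measurements. Within the data shown here, compound 1 and compound 2 differ in two places, so no single step between them can be read off; the two values only show that the pair carrying two methoxyphenyl rings sits far weaker than the pair carrying phenyl and chlorophenyl.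

Compound 3, `COc1ccc(C2=NN(C3=NC(=O)/C(=C4\C(=O)Nc5ccccc54)S3)C(c3ccc(Cl)cc3)C2)cc1`, has not yet been measured in this assay. It differs from compound 2 in one place: methoxy in place of hydrogen on an aromatic carbon. This moves compound 3 halfway toward the substitution pattern of compound 1.

Because compound 1 gives 100000 nM while compound 2 gives 190 nM, the methoxy on this ring is expected to cost potency; the step of a 13-fold higher number from compound 2 to compound 3 (1.12 log units; beyond the scatter) is estimated to run upward, beyond the scatter, though short of the full gap to compound 1. Compound 3 is therefore expected at 2500 nM, within 400 nM to 30000 nM.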

Compound 3, concentration for 50% growth inhibition: 100000 nM
Estimate against measurement, compound 3: 40-fold (1.60 log units) below; measured number outside the range, above it.
By their numbers in this assay, from the lowest: compound 2; then compounds 1 and 3 (each within the scatter of the next).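

In this assay, the change from phenyl to 4-methoxyphenyl, with the rest of compound 2 untouched, gives a 530-fold higher number from compound 2 to compound 3 (2.72 log units; beyond the scatter), so this one methoxy, para to a large group, is enough on its own to span the whole gap that the earlier pair showed across two places. The second place, read with methoxy already on this ring, gives no change at the digits printed from compound 1 to compound 3 (within the scatter) for chloro in place of methoxy on an aromatic carbon, so the exchange of these two groups there shows no effect on growth inhibition in this setting, and the two-place gap between compound 1 and compound 2 can be read through compound 3 as resting on the methoxy step alone. No measurement in hand bears on why this methoxy costs so much.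

Open, going by these compounds, is whether the loss belongs to methoxy itself or extends to other groups on this ring, such as a hydroxyl, an amine, a fluorine or a longer ethoxy chain. Also open, on these data alone, is whether chloro at the second place matters once this ring carries hydrogen, since the step read here holds only with methoxy present.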